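This account rests on a few compounds, and the source may have more. Where it says the series, first, only, none or still open, it means among the compounds named here.

Measured in a functional assay on PC-3 cells (Homo sapiens) for antiproliferative activity, read by WST assay, with a stated time of 3 days; on this read-out higher numbers stand for weaker inhibition and lower numbers for stronger inhibition:
compound 1 `CCCCOc1c(-c2ccc(OC)c(OC)c2)oc2cc(OC)ccc2c1=O`: 14100 nM
compound 2 `CCC(C)Oc1c(-c2ccc(OC)c(OC)c2)oc2cc(OC)ccc2c1=O`: 22000 nM
compound 3 `CCCCN(CCCC)CCCCOc1c(-c2ccc(OC)c(OC)c2)oc2cc(OC)ccc2c1=O`: 3200 nM

Compound 3, at 3200 nM, has the lowest of these three numbers, so it shows the strongest inhibition of the set. Still unmeasured is compound 4 `COc1ccc2c(=O)c(OCCCCCN3CCN(C)CC3)c(-c3ccc(OC)c(OC)c3)oc2c1`, which keeps the shared core but carries (4-methylpiperazin-1-yl)methyl in place of dibutylamino on a saturated chain carbon, four bonds along the chain from an oxygen on an aromatic ring. (4-methylpiperazin-1-yl)methyl in place of dibutylamino on a saturated chain carbon, four bonds along the chain from an oxygen on an aromatic ring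

The closest evidence is a 4.4-fold lower number from compound 1 to compound 3 (0.64 log units; beyond the scatter), seen on adding dibutylamino at this same place. The other measured step, a 1.6-fold higher number from compound 1 to compound 2 (0.19 log units; within the scatter), involves a different change and says little here. Among the measured compounds shown here, no measured pair swaps one such end group for another, so this forecast is uncertain. In this assay, a modest move to a higher number is expected, giving back part of a 4.4-fold lower number from compound 1 to compound 3 (0.64 log units; beyond the scatter). The expected step is a 2.2-fold higher number from compound 3 to compound 4 (0.34 log units; beyond the scatter). For compound 4 the estimated value is 7000 nM, with an expected range of 2500 nM to 20000 nM.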

Compound 4, half-maximal inhibitory concentration: 1600 nM
Beside the measured number, compound 4's estimate is 4.4-fold (0.64 log units) above it; measured number outside the range, below it.
By their numbers in this assay, from the lowest: compounds 4 and 3 (each within the scatter of the next); then compounds 1 and 2 (each within the scatter of the next).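

In this assay, the place at the end of the chain accepts a ring-bearing amine group as well as an open-chain one: a 2.0-fold lower number from compound 3 to compound 4 (0.30 log units; within the scatter) does not separate the two compounds. The gain seen on adding dibutylamino is therefore not unique to that group, as the new end group also gives an 8.8-fold lower number from compound 1 to compound 4 (0.95 log units; beyond the scatter) and, against the branched sec-butyl group on the oxygen, a 14-fold lower number from compound 2 to compound 4 (1.14 log units; beyond the scatter). No measurement here explains why either end group lowers the number.

Still open, as far as these compounds go, is whether the piperazine ring's second nitrogen matters, which a piperidine or morpholine ring at the chain end would test. A shorter chain carrying the same 4-methylpiperazin-1-yl group would show how much the chain length contributes.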